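The source may hold more compounds than are shown below. What is called first, only, known or untested is meant among the compounds shown, and "the series" means these compounds.

Compound 3 `CC1(C)Oc2ccc(C#N)cc2[C@H](N(CC(=O)O)c2ccccc2)[C@H]1O` is the weakest point in this set: in a functional assay (aorta) with Rattus norvegicus as the target (a lower number here means a stronger inhibitor, a higher number a weaker inhibitor), compound 3 reaches only the limit > 100000 nM, so no number is known for it. Its parent compound 2 `CC1(C)Oc2ccc(C#N)cc2[C@H](Nc2ccccc2)[C@H]1O` gives 1200 nM in this assay. The step of an at least 83-fold higher number from compound 2 to compound 3 (1.92 log units; beyond the scatter) is therefore large, and it ends at the limit of > 100000 nM in this assay, at which 1 of the 3 values shown sits. Compound 1 `CCOC(=O)CN(c1ccccc1)[C@@H]1c2cc(C#N)ccc2OC(C)(C)[C@H]1O` carries an ethoxycarbonylmethyl group on the same nitrogen; in this assay compound 1 likewise reaches only a limit, > 30000 nM, which is the limit of > 30000 nM in this assay, at which 1 of the 3 values shown sits.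

Compound 4 `CCOC(=O)CCCN(c1ccccc1)[C@H]1c2cc(C#N)ccc2OC(C)(C)[C@@H]1O` is the next step, with 2-(ethoxycarbonyl)ethyl in place of carboxy on a saturated chain carbon bound to a nitrogen on an aromatic ring. Going by the values given here, no measured step covers this change directly; the only step that bears on it, from compound 2 to compound 3, shows that substitution on this nitrogen removed activity, and compound 1 shows that a chain ending in an ethoxycarbonyl group on this nitrogen gave no measurable number either. The expected step of an at least 1.6-fold lower number from compound 3 to compound 4 (0.22 log units; that floor lies within the scatter) is therefore none beyond the scatter, and compound 4 is estimated at 60000 nM, in the range 10000 nM to 300000 nM, most likely reported again only as a limit.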

Compound 4, half-maximal inhibitory concentration: > 30000 nM
Compound 4 gave a limit, no number; the forecaster's own chance of this, stated with the estimate: 70%; the middle value does not contradict the limit.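

In this assay compound 4 reaches only a limit, > 30000 nM. The 3-(ethoxycarbonyl)propyl group thus joins carboxymethyl as a replacement for hydrogen on this nitrogen that loses activity, with an at least 25-fold higher number from compound 2 to compound 4 (1.39 log units; beyond the scatter), so the longer chain ending in an ester did not restore a measurable number. The steps between the substituted compounds cannot be read, as their values are all limits, and the effects of chain length and of ester against acid therefore stay unseparated.

Of the compounds shown, only compound 2, with hydrogen on this nitrogen, gives a number, 1200 nM. As far as these compounds go, it remains open whether any substituent there keeps activity, for example a methyl group or a chain ending in an amine.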